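Hydroxyphenyl swap from compound 2 to compound 3

The source may report more compounds than this note shows. Statements on the series, on what has been measured and on what is new or still open speak of the compounds shown alone.

Values in a functional assay on T47D cells (Homo sapiens) for inhibition (on this read-out lower numbers stand for stronger inhibition and higher numbers for weaker inhibition), so far:
- Compound 1 `Oc1ccccc1-c1cc(-c2ccc(F)cc2)cc(-c2ccccc2O)n1` gives > 50000 nM as a limit
- Compound 2 `Oc1ccc(-c2cc(-c3ccc(F)cc3)cc(-c3ccccc3O)n2)cc1` gives > 50000 nM as a limit
- Compound 3 `Oc1ccc(-c2cc(-c3ccc(F)cc3)cc(-c3cccc(O)c3)n2)cc1` is not yet measured

Compound 2 has no numerical value, only the limit > 50000 nM in this assay. For the measured compounds named here, the same holds across the series so far, with the limit of > 50000 nM in this assay, at which 2 of the 2 values shown sit, as the whole of the evidence.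

Compound 3 differs from compound 2 in one place, with 3-hydroxyphenyl in place of 2-hydroxyphenyl next to the ring nitrogen: 3-hydroxyphenyl in place of 2-hydroxyphenyl on an aromatic carbon. Going by the values given here, the one measured step that bears on this change also replaces a 2-hydroxyphenyl group, this time with 4-hydroxyphenyl, and it reads a step that the two limits leave unreadable from compound 1 to compound 2. No size can be carried over from it, so the expectation is weakly founded. With compound 2 at the limit > 50000 nM, any readable change could only be towards stronger inhibition, and a modest one at that is expected. The estimated step is an at least 1.4-fold lower number from compound 2 to compound 3 (0.15 log units; that floor lies within the scatter), and a further limit reading would be no surprise. For compound 3 the expected value is 35000 nM, with an estimated range of 8000 nM to 50000 nM.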

Compound 3, half-maximal inhibitory concentration: 5000 nM
Compound 3: middle estimate off by 7.0-fold (0.85 log units), on the high side; measured number outside the range, below it.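

In this assay this position gives the series its first reading that is a number and not a limit: 3-hydroxyphenyl in place of 2-hydroxyphenyl next to the ring nitrogen is an at least 10-fold lower number from compound 2 to compound 3 (1.00 log units; beyond the scatter). The earlier step, 4-hydroxyphenyl in place of 2-hydroxyphenyl, cannot be read, so the placing of the hydroxyl on this phenyl group had shown nothing until now; among the compounds shown, compound 3 is the only one that carries no 2-hydroxyphenyl group and the only one with a numerical value. The step is a floor and not a measured size, since compound 2 holds only a limit: the limit of > 50000 nM in this assay, at which 2 of the 3 values shown sit.

Still open, on these data alone, is whether the hydroxyl itself matters at this position, which a 3-methoxyphenyl or 3-aminophenyl group in place of the 3-hydroxyphenyl group would address. Also open is whether the effect of the 3-hydroxyphenyl group depends on the 4-hydroxyphenyl group that compound 3 keeps, as no compound shown pairs 3-hydroxyphenyl with any other group at that second place.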